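The compounds below may be only part of what the source reports. "The series", "measured", "known", "first", "only" and "open" are said of these compounds alone.

Measured compounds:
- compound 1 `O=[N+]([O-])c1cn2c(n1)OC(COc1ccc(-c3ccc(C(F)(F)F)cc3)cn1)C2` — 45000 nM
- compound 2 `O=[N+]([O-])c1cn2c(n1)OC(COc1ccc(-c3ccc(OC(F)(F)F)cc3)cn1)C2` — 47000 nM
- compound 3 `O=[N+]([O-])c1cn2c(n1)OC(COc1ccc(-c3ccc(C(F)(F)F)cc3)nc1)C2` — > 64000 nM

In an ADME assay on MRC5 cells (Homo sapiens) for cytotoxicity, read by fluorescence, with a stated time of 72 h (on this read-out higher numbers stand for weaker inhibition and lower numbers for stronger inhibition), compound 1 gives 45000 nM. Compound 2 gives 47000 nM in this assay. For compound 3 the result in this assay is a limit of the assay and not a number, > 64000 nM.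

The change from compound 1 to compound 2 is trifluoromethoxy in place of trifluoromethyl on an aromatic carbon; it gave a 1.0-fold higher number from compound 1 to compound 2 (0.02 log units; within the scatter). How the core of compound 3 differs from the core of compound 1 is not broken down here; the two values show that compound 3 sits at the limit of > 64000 nM in this assay, at which 1 of the 3 values shown sits, while compound 1 does not.

Compound 4 `O=[N+]([O-])c1cn2c(n1)OC(COc1ccc(-c3ccc(OC(F)(F)F)cc3)nc1)C2` has not yet been measured. It stands to compound 3 exactly as compound 2 stands to compound 1: trifluoromethoxy in place of trifluoromethyl on an aromatic carbon. Since this same change gave a 1.0-fold higher number from compound 1 to compound 2 (0.02 log units; within the scatter), compound 4 is expected to give about a step that the limit leaves unreadable from compound 3 to compound 4 in this assay. Because compound 3 already sits at the limit of > 64000 nM in this assay, at which 1 of the 3 values shown sits, compound 4 is estimated at 70000 nM, between 45000 nM and 130000 nM, and the assay is expected most likely to report only a limit again.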

Compound 4, half-maximal inhibitory concentration: > 64000 nM
Compound 4 was reported as a limit; the forecaster's own chance of this, stated with the estimate: 70%; the middle value lies beyond the limit too.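

In this assay compound 4 gives > 64000 nM, a limit of the assay and not a number, and compound 3 is also reported only as a limit, so no step can be read between them: the limit of > 64000 nM in this assay, at which 2 of the 4 values shown sit.

The compounds shown leave open what numbers compound 3 and compound 4 would give, and so whether trifluoromethoxy in place of trifluoromethyl matters on the core of compound 3.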